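The compounds below may be only part of what the source reports. "The series", "measured", "known", "first", "only" and "open" are said of these compounds alone.

Measured in a functional assay on T-24 cells (Homo sapiens) for antiproliferative activity, read by MTT assay, with a stated time of 72 h; a higher number here means a weaker inhibitor, a lower number a stronger inhibitor:
compound 1 `N=C(NC(=N)NC1CCCC1)Nc1ccc(C(F)(F)F)cc1` gives 3700 nM
compound 2 `CC(C)CNC(=N)NC(=N)Nc1ccc(C(F)(F)F)cc1` gives 3100 nM
compound 3 `CCN(CC)C(=N)NC(=N)Nc1ccc(C(F)(F)F)cc1` gives 6200 nM

Compound 3 carries the highest of the three numbers, but it is not set apart from the others: a 1.7-fold higher number from compound 1 to compound 3 (0.22 log units; within the scatter) and a 2.0-fold higher number from compound 2 to compound 3 (0.30 log units; within the scatter) both stay within the scatter, and a 1.2-fold lower number from compound 1 to compound 2 (0.08 log units; within the scatter) does the same, so no order among the three compounds can be read from these values. All three share one core and differ only in the substituent on the terminal amine nitrogen, and across cyclopentylamino, isobutylamino and diethylamino that substituent has not moved the number beyond the scatter.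

Compound 4 `CCN(C)C(=N)NC(=N)Nc1ccc(C(F)(F)F)cc1` continues the same line of variation: hydrogen in place of methyl on a saturated chain carbon bound to an amine nitrogen. Within the data shown here, the steps that bear on it are the two exchanges leading into compound 3, and both were small. Trimming a single methyl from the diethylamino group is a smaller change than either of those, so no step beyond the scatter is expected in this assay, in either direction. Compound 4 is therefore estimated at 5500 nM, with a range from 2800 nM to 11000 nM. That estimate corresponds to an expected step of a 1.1-fold lower number from compound 3 to compound 4 (0.05 log units; within the scatter).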

Compound 4, half-maximal inhibitory concentration: 5700 nM
The estimate for compound 4 lay 1.0-fold (0.02 log units) below the measured number, within the range that was stated.
By their numbers in this assay, from the lowest: compounds 2, 1, 4 and 3 (each within the scatter of the next).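

In this assay, cutting the diethylamino group down to ethyl(methyl)amino, with hydrogen in place of methyl on a saturated chain carbon bound to an amine nitrogen, gives a 1.1-fold lower number from compound 3 to compound 4 (0.04 log units; within the scatter), so this smallest exchange in the series has no readable effect on the number. The ethyl(methyl)amino group also stays level with the two groups carrying a hydrogen on that nitrogen, with a 1.8-fold higher number from compound 2 to compound 4 (0.26 log units; within the scatter) against isobutylamino and a 1.5-fold higher number from compound 1 to compound 4 (0.19 log units; within the scatter) against cyclopentylamino, which extends the flat picture to four substituents and leaves no order among compounds 1, 2, 3 and 4. No supporting data bear on this flat result.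

Still open, as far as these compounds go, is whether any group at this nitrogen can move the number beyond the scatter, for example a much longer chain or a chain ending in a carboxylic acid or a further amine. From the compounds shown here alone, all four compounds also keep the trifluoromethyl group on the shared core, so what a nitrile or a chlorine there would do to the number remains unknown.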